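Halogen exchange on a shared core and cytotoxicity

The source may hold more compounds than are shown below. What is called first, only, known or untested is meant among the compounds shown, and "the series" means these compounds.

Compound 1, `Nc1ncc(Br)c2c1ncn2[C@@H]1C[C@H](O)[C@@H](O)[C@H]1O`, reaches in an ADME assay on HFF cells (Homo sapiens) for cytotoxicity (on this read-out higher numbers stand for lower toxicity in this test and lower numbers for higher toxicity in this test), only the limit > 300000 nM.
Compound 2, `Nc1ncc(I)c2c1ncn2[C@@H]1C[C@H](O)[C@@H](O)[C@H]1O`, gives in this assay 201000 nM.

Compound 2 holds the only number shown in this assay; the other entry is a limit, not a number. For the measured compounds named here, the single measured step, an at least 1.4-fold lower number from compound 1 to compound 2 (0.17 log units; that floor lies within the scatter), rests on that limit, (the limit of > 300000 nM in this assay, at which 1 of the 2 values shown sits), so its true size stays open. Compound 3, `Nc1ncc(Cl)c2c1ncn2[C@@H]1C[C@H](O)[C@@H](O)[C@H]1O`, differs from compound 2 by chloro in place of iodo on an aromatic carbon. This reverses the direction of the bromo-to-iodo step and moves one further along the halogens. With one step only, and its floor within the scatter, no change beyond the scatter can be asserted, but compound 1 at the limit of > 300000 nM in this assay, at which 1 of the 2 values shown sits, points toward a high value for compound 3. Compound 3 is therefore expected to reach about 300000 nM, with a range of 120000 nM to 700000 nM, quite possibly again as a limit. That estimate corresponds to an expected step of a 1.5-fold higher number from compound 2 to compound 3 (0.17 log units; within the scatter).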

Compound 3, half-maximal cytotoxic concentration: > 300000 nM
Compound 3: a limit, no number; the forecaster's own chance of this, stated with the estimate: 60%; the middle value sits exactly at the limit.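

Among the halogens shown at this position, para to an amino group, only iodo in compound 2 gives a number in this assay; compound 3, with chloro, gives only a limit, as compound 1 with bromo does. Going from iodo to chloro gives an at least 1.4-fold higher number from compound 2 to compound 3 (0.17 log units; that floor lies within the scatter), so this step, like the earlier one, shows no change beyond the scatter and its true size stays open. The step from compound 1 to compound 3 cannot be read because both entries are limits: the limit of > 300000 nM in this assay, at which 2 of the 3 values shown sit.

The compounds shown leave open how far the chloro and bromo values actually lie from the iodo value, and whether these halogens differ at all in this test. Also open, going by these compounds, is how a methyl group, a nitrile or a carboxylic acid on this aromatic carbon would read in this assay.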